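The source may hold more compounds than are shown below. What is called first, only, known or untested is meant among the compounds shown, and "the series" means these compounds.

In a functional assay on the whole organism with Mus musculus as the target (on this read-out higher numbers stand for an effect only at larger amounts of compound and lower numbers for an effect already at smaller amounts), compound 1 `O=c1oc2cccnc2n1CCN1CCN(c2ccc(F)cc2)CC1` gives 41.3 mg/kg, the higher of the two numbers reported, and a number within the usual scatter is expected for compound 4. Compound 3 `O=c1oc2cccnc2n1CN1CCN(c2ccc(F)cc2)CC1` gives 3.5 mg/kg in this assay, a gap to compound 1 beyond the scatter. Compound 2 `Cc1ccc2oc(=O)n(CCN3CCN(c4ccccc4)CC3)c2n1` reaches only the limit of this assay, > 50 mg/kg, and not a number. Compound 4 `O=c1oc2cccnc2n1CCN1CCN(c2ccc(Cl)cc2)CC1` has not yet been measured; it differs from compound 1 by chloro in place of fluoro on an aromatic carbon. Within the data shown here, with no measured step of this kind to draw on, the step of a 1.2-fold lower number from compound 1 to compound 4 (0.07 log units; within the scatter) is expected to be small, with no clear direction. Compound 4 is therefore estimated at 35 mg/kg in this assay, within a range from 12 mg/kg to 100 mg/kg.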

Compound 4, dose for half-maximal effect: > 50 mg/kg
Compound 4: a limit, no number; the forecaster's own chance of this, stated with the estimate: 35%; middle value at least 1.4-fold (0.15 log units) from the limit.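

The result for compound 4 is a limit of this assay, not a number. Chloro in place of fluoro on this aromatic carbon gives an at least 1.2-fold higher number from compound 1 to compound 4 (0.08 log units; that floor lies within the scatter), which is only a floor and shows no loss beyond the scatter on its own. How far the true value lies past that floor cannot be told, because the read-out ends at this limit: the limit of > 50 mg/kg in this assay, at which 2 of the 4 values shown sit.

Going by these compounds, what a methoxy group or an amine would give at this place stays open. So does whether chloro and fluoro would compare in the same way on the chain of compound 3.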